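The source may report more compounds than this note shows. Statements on the series, on what has been measured and on what is new or still open speak of the compounds shown alone.

Compound 1 `CCn1cc(-c2ccnc3[nH]c(C4CCN(CC(=O)N(C)C)CC4)cc23)ccc1=O` and compound 2 `COc1cc(=O)n(C)cc1-c1ccnc2[nH]c(C3CCN(CC(=O)N(C)C)CC3)cc12` share their core with compound 3 `CN(C)C(=O)CN1CCC(c2cc3c(-c4ccc(=O)n(CC5CCOCC5)c4)ccnc3[nH]2)CC1`, differing from it only in the group attached to the saturated chain carbon bound to an aromatic nitrogen, or in the ring that carries it. In an ADME assay on microsomes from liver (Homo sapiens) for metabolic stability (on this read-out lower numbers stand for slow clearance and higher numbers for fast clearance), compound 1 gives < 3 uL/min, which is a limit of the assay rather than a number. Compound 2 likewise gives < 3 uL/min, also a limit. Compound 3 gives 20 uL/min and is the only one of the three reported as a number. The step that the two limits leave unreadable from compound 1 to compound 2 cannot be read because both of its ends sit at the limit of < 3 uL/min in this assay, at which 2 of the 3 values shown sit. The step of an at least 6.6-fold higher number from compound 1 to compound 3 (0.82 log units; beyond the scatter) is the one that bears on the change now in hand. Compound 4 `CN(C)C(=O)CN1CCC(c2cc3c(-c4ccc(=O)n(C)c4)ccnc3[nH]2)CC1` differs from compound 3 by hydrogen in place of oxan-4-yl on a saturated chain carbon bound to an aromatic nitrogen, which largely undoes that earlier step, with hydrogen in place of oxan-4-yl. A drop of roughly the same size is therefore expected, most likely back to the limit. Compound 4 is expected to give 3 uL/min, within a range of 1 uL/min to 8 uL/min. The expected step is a 6.7-fold lower number from compound 3 to compound 4 (0.82 log units; beyond the scatter).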

Compound 4, intrinsic clearance in a liver preparation (reported as CLH), per the amount of preparation that the assay uses: < 3 uL/min
Compound 4: a limit, no number (the forecaster's own chance of this, stated with the estimate: 65%); the middle value sits exactly at the limit.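

Going from (oxan-4-yl)methyl to methyl gives an at least 6.6-fold lower number from compound 3 to compound 4 (0.82 log units; beyond the scatter) in this assay, so on this otherwise unchanged compound the higher number goes with the oxan-4-yl group. Compound 4 gives < 3 uL/min, which is a limit of the assay and not a number. The steps to compound 4 from compound 1 and from compound 2 cannot be read, so the methyl and ethyl groups on this nitrogen cannot be told apart, because both ends of each step sit at one limit: the limit of < 3 uL/min in this assay, at which 3 of the 4 values shown sit.

The compounds shown leave open whether the whole ring or only its oxygen goes with the higher number. A cyclohexylmethyl group, with carbon in place of the ring oxygen, or a longer chain such as butyl in the same place would bear on this.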